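The source may hold more compounds than are shown below. What is called first, only, known or untested is meant among the compounds shown, and "the series" means these compounds.

Measured so far:
compound 1 `COc1cc(C(=O)O)ccc1OCCCCOc1ccc(C(=O)C(C)C)c(O)c1C` — "not determined" (no result reported)
compound 2 `Cc1c(OCCCCOc2ccc(C(=O)O)cc2)ccc(C(=O)CC2CCCC2)c1O` — > 10000 nM
compound 3 `COC(=O)c1ccc(OCCCCOc2ccc(C(=O)CC3CCCC3)c(O)c2C)cc1` — "not determined" (no result reported)

In an assay on HEK293 cells for positive allosteric modulation of metabotropic glutamate receptor 3 (Rattus norvegicus), read by thallium flux, with a stated time of 2.5 min (a higher number here means that more compound is needed for the effect, a lower number that less compound is needed), compound 1 shows "not determined" (no result reported) and compound 3 shows "not determined" (no result reported); both are blanks. For compound 2 the entry > 10000 nM is a limit of the assay, not a number, and it sits at the limit of > 10000 nM in this assay, at which 1 of the 3 values shown sits. Among the compounds with values here, compound 3 therefore stands nowhere on the numbers: its only neighbour with a result is compound 2, and no measured step joins them.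

Compound 4 `Cc1c(OCCCCOCOc2ccc(C(=O)O)cc2)ccc(C(=O)CC2CCCC2)c1O` is to be measured next. ((4-carboxyphenoxy)methyl in place of 4-(methoxycarbonyl)phenyl on an oxygen on a saturated carbon). No measured step sizes this change, so no direction beyond the scatter can be claimed in this assay. Compound 4 shares the free acid of compound 2, whose result is > 10000 nM, so a limit is the likelier outcome again. Compound 4 is expected near 15000 nM, within 4000 nM to 60000 nM.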

Compound 4, half-maximal effective concentration: 1910 nM
Compound 4: the middle estimate sits 7.9-fold (0.90 log units) above what was measured; measured number below the stated range.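

In this assay, (4-carboxyphenoxy)methyl in place of 4-carboxyphenyl on an oxygen on a saturated carbon gives an at least 5.2-fold lower number from compound 2 to compound 4 (0.71 log units; beyond the scatter). Within the data shown here, compound 4 thus provides the first single number, so the free acid does not exclude a measurable result at this position. Compound 2 gives a limit of the assay, not a number, so the true size of the step stays unknown: the limit of > 10000 nM in this assay, at which 1 of the 4 values shown sits.

As far as these compounds go, whether a methyl ester or an amide in place of the carboxylic acid of compound 4 would shift the number remains open. Also open, from the compounds shown here alone, is the effect of a longer chain on that oxygen.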